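A few compounds are considered here, and "the series" means these few. Any claim that something is new, unique, unknown or untested is made for them only; others in the source may bear on it.

Measured so far in a functional assay on SGC-7901 cells (Homo sapiens) for antiproliferative activity, read by MTT assay, with a stated time of 72 h; a higher number here means a weaker inhibitor, a lower number a stronger inhibitor:
compound 1 `CCOc1ccc(-c2ccc3ncn(-c4cc(OC)c(OC)c(OC)c4)c3c2)cc1`, 2970 nM
compound 2 `COc1ccc(-c2ccc3ncn(-c4cc(OC)c(OC)c(OC)c4)c3c2)cc1O`, 44 nM
compound 3 `COc1cc(-n2cnc3ccc(-c4cc(F)ccc4F)cc32)cc(OC)c1OC`, 6590 nM

Compound 1 stands second highest of the three numbers. Its nearest neighbour is reached by the step of a 2.2-fold higher number from compound 1 to compound 3 (0.35 log units; beyond the scatter), its furthest by the step of a 68-fold lower number from compound 1 to compound 2 (1.83 log units; beyond the scatter).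

Compound 4 `COc1cc(-n2cnc3ccc(-c4ccc(Cl)cc4)cc32)cc(OC)c1OC` differs from compound 1 in one place: chloro in place of ethoxy on an aromatic carbon. Going by the values given here, two measured steps bear on it, both starting from compound 1. The step of a 2.2-fold higher number from compound 1 to compound 3 (0.35 log units; beyond the scatter) is the closer analogy, since there too the ethoxy-bearing ring was exchanged for one carrying halogen only, with no hydrogen-bond acceptor left on that ring, and the result was a modest rise in the number. The step of a 68-fold lower number from compound 1 to compound 2 (1.83 log units; beyond the scatter) shows that this position can move the number a great deal, but it moved it downward with a ring carrying a hydroxyl, which compound 4 does not have. For compound 4 a step of the same modest kind as that to compound 3, upward or none beyond the scatter, is therefore expected, a 1.4-fold higher number from compound 1 to compound 4 (0.15 log units; within the scatter). Compound 4 is estimated at 4200 nM, in the range 1500 nM to 12000 nM.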

Compound 4, half-maximal inhibitory concentration: 1270 nM
Compound 4: middle estimate off by 3.3-fold (0.52 log units), on the high side; measured number below the stated range.
By their numbers in this assay, from the lowest: compound 2; then compound 4; then compound 1; then compound 3.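

In this assay, halogen-only rings do not act as a single class at this position: a 2.3-fold lower number from compound 1 to compound 4 (0.37 log units; beyond the scatter), which runs opposite in direction to a 2.2-fold higher number from compound 1 to compound 3 (0.35 log units; beyond the scatter), while a 5.2-fold lower number from compound 3 to compound 4 (0.72 log units; beyond the scatter) separates the two halogen-bearing rings. Exchanging ethoxy for chloro removes the hydrogen-bond acceptor counted in the leaving group, yet the number still falls, so in this pair a ring without that acceptor does not raise the number, and the direction of the step depends on which halogen-bearing ring enters. Even so, a 29-fold higher number from compound 2 to compound 4 (1.46 log units; beyond the scatter), so 4-chlorophenyl closes only a small part of the distance to the 3-hydroxy-4-methoxyphenyl ring, which remains alone at the low end of these four compounds.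

The compounds shown leave open whether chloro itself or the absence of substitution elsewhere on the ring sets the difference from 2,5-difluorophenyl, and how an amine or a carboxylic acid in place of chloro on this ring would compare. No measurement at hand accounts for any of these differences.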